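Removing the para bromine from a thiophene ester amide

The compounds below may be only part of what the source reports. "The series", "measured", "known", "first", "only" and "open" are said of these compounds alone.

Measured compounds:
- compound 1, `COC(=O)c1sccc1NC(=O)CSc1cccc(OC)c1`: 575 nM
- compound 2, `COC(=O)c1sccc1NC(=O)CSc1ccc(OC)cc1`: 871 nM
- compound 3, `COC(=O)c1sccc1NC(=O)CSc1ccc(Br)cc1`: 427 nM

All three share the same core and differ only in the substituent on the outer phenyl ring. In an assay on H9c2 cells for inhibition of tumor necrosis factor receptor superfamily member 6 (Rattus norvegicus), with stated times of 30 min and 6 h (on this read-out lower numbers stand for an effect already at smaller amounts and higher numbers for an effect only at larger amounts of compound), compound 3 gives the lowest of the three numbers, but compound 1 sits within the usual scatter of it, so the two cannot be ranked; only compound 2 is separated from compound 3 by a step beyond the scatter, namely a 2.0-fold lower number from compound 2 to compound 3 (0.31 log units; beyond the scatter).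

The next compound, compound 4, `COC(=O)c1sccc1NC(=O)CSc1ccccc1`, removes the halogen altogether: hydrogen in place of bromo on an aromatic carbon. Within the data shown here, no measured step exchanges bromo for hydrogen, so the one step that bears on it does so only loosely: the exchange of methoxy for bromo on the same ring carbon produced a 2.0-fold lower number from compound 2 to compound 3 (0.31 log units; beyond the scatter), a modest gain. Taking the bromo away again is therefore expected to cost something of that gain, though the unsubstituted ring has no direct precedent among these compounds and the outcome could also fall within the scatter.

Compound 4 is accordingly estimated at 650 nM in this assay , with a plausible range from 300 nM to 1500 nM, which corresponds to an expected step of a 1.5-fold higher number from compound 3 to compound 4 (0.18 log units; within the scatter).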

Compound 4, half-maximal effective concentration: 794 nM
Compound 4: the middle estimate sits 1.2-fold (0.09 log units) below what was measured, within the range that was stated.
By their numbers in this assay, from the lowest: compounds 3, 1, 4 and 2 (each within the scatter of the next, the first and the last beyond it).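

In this assay, taking the bromo away leaves only a 1.9-fold higher number from compound 3 to compound 4 (0.27 log units; within the scatter), so at this ring carbon, para to a large group, removing the halogen does not by itself give a step beyond the scatter, although the exchange of methoxy for bromo did. Among these compounds, the plain phenyl ring also cannot be separated from either methoxy compound, with a 1.1-fold lower number from compound 2 to compound 4 (0.04 log units; within the scatter) for the methoxy at this same carbon and a 1.4-fold higher number from compound 1 to compound 4 (0.14 log units; within the scatter) for the other methoxy isomer, so compound 4 lies within the scatter of all three earlier compounds and the only separated pair remains compound 2 and compound 3, which means neither bromo nor methoxy stands out clearly against hydrogen here. There is no supporting evidence to explain these small differences.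

Going by these compounds, it remains open whether any group at this ring carbon, such as an amine, a carboxylic acid or a longer alkyl chain, would give a step clearly beyond the scatter from hydrogen. The compounds shown also leave open what happens when the methyl ester of the shared core gives way to a carboxylic acid, since every compound here keeps that ester.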